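The source may report more compounds than this note shows. Statements on the series, on what has been measured and on what is new or still open speak of the compounds shown alone.

Measured so far in an assay on HEK293 cells for displacement of a labelled ligand from NPC1-like intracellular cholesterol transporter 1 (Homo sapiens); on this read-out lower numbers stand for stronger inhibition and higher numbers for weaker inhibition:
compound 1 `CC(C)(C)c1ccc(C(=O)N2CCC3(CC2)C(=O)N(CC(=O)N2CCC(CCO)CC2)CN3c2ccccc2)cc1`, 2600 nM
compound 2 `CC(C)(C)OC(=O)NC1CCN(C(=O)CN2CN(c3ccccc3)C3(CCN(C(=O)c4ccc(C(C)(C)C)cc4)CC3)C2=O)CC1`, 8300 nM
compound 3 `CCOC(=O)C1CCN(C(=O)CN2CN(c3ccccc3)C3(CCN(C(=O)c4ccc(C(C)(C)C)cc4)CC3)C2=O)CC1`, 3100 nM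

Compound 3 holds the second highest of these three numbers; its nearest neighbour is compound 1, with a 1.2-fold higher number from compound 1 to compound 3 (0.08 log units; within the scatter), a step within the scatter, while compound 2 lies further off, with a 2.7-fold lower number from compound 2 to compound 3 (0.43 log units; beyond the scatter). Compound 4 `CCc1nn(CC)c(C2CCN(C(=O)CN3CN(c4ccccc4)C4(CCN(C(=O)c5ccc(C(C)(C)C)cc5)CC4)C3=O)CC2)c1C` differs from compound 3 in one place: 1,3-diethyl-4-methyl-1H-pyrazol-5-yl in place of ethoxycarbonyl on a saturated ring carbon. Both measured steps swap the group on a saturated ring carbon and stay small, so varied groups there give similar numbers, though none of them contains a five-membered aromatic ring. The step expected in this assay is accordingly small, a 1.1-fold higher number from compound 3 to compound 4 (0.05 log units; within the scatter), with either direction possible. Compound 4 is estimated at 3500 nM, within a range from 1000 nM to 12000 nM.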

Compound 4, half-maximal inhibitory concentration: 2500 nM
For compound 4 the middle estimate is 1.4-fold (0.15 log units) above the measured one; measured number inside the range.
By their numbers in this assay, from the lowest: compounds 4, 1 and 3 (each within the scatter of the next); then compound 2.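

In this assay, this saturated ring carbon also accepts a five-membered aromatic ring: swapping ethoxycarbonyl, 5 heavy atoms, for 1,3-diethyl-4-methyl-1H-pyrazol-5-yl, 10 heavy atoms, gives a 1.2-fold lower number from compound 3 to compound 4 (0.09 log units; within the scatter), and the comparison with 2-hydroxyethyl gives a 1.0-fold lower number from compound 1 to compound 4 (0.02 log units; within the scatter). Only the (tert-butoxycarbonyl)amino group stands apart from the new ring, with a 3.3-fold lower number from compound 2 to compound 4 (0.52 log units; beyond the scatter). No supporting data explain these results.

From the compounds shown here alone, whether a free amine or a carboxylic acid on this carbon would keep the number in the same region remains open. So does whether a pyrazole without its ethyl groups would match this one.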